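Swapping One Aryl Group on a Growth Inhibitor

The source may report more compounds than this note shows. Statements on the series, on what has been measured and on what is new or still open speak of the compounds shown alone.

In a functional assay on MIA PaCa-2 cells (Homo sapiens) for inhibition, read by MTT assay, with a stated time of 72 h, tested at 30 uM (a higher number here means more inhibition of growth at the concentration tested, a lower number less inhibition of growth), compound 1 (`C=CCc1ccc(OCc2cn(-c3ccc(C#N)cc3)nn2)c(O)c1`) gives 39.3%, and compound 2 (`C#CCOc1ccc(CC=C)cc1O`) gives 27.4%. Within the data shown here, compound 1 stands highest of the two numbers so far, and the gap to compound 2 lies beyond the scatter. Compound 3 (`C=CCc1ccc(OCc2cn(-c3ccccc3CO)nn2)c(O)c1`) keeps the core of compound 1 but carries 2-(hydroxymethyl)phenyl in place of 4-cyanophenyl on an aromatic nitrogen. Among the measured compounds shown here, no measured pair shows what such a swap does, so only a small downward move in this assay is expected, an estimated a number 6.3 percentage points lower from compound 1 to compound 3 (within the scatter) that may stay within the scatter. The estimated value for compound 3 is 33% (15% to 50%).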

Compound 3, percent growth inhibition at one concentration: 39.6%
Compound 3: the middle estimate sits 6.6 percentage points below what was measured, and the stated range covers the measured number.
By their numbers in this assay, from the lowest: compound 2; then compounds 1 and 3 (each within the scatter of the next).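

On the aromatic nitrogen, 2-(hydroxymethyl)phenyl in place of 4-cyanophenyl gives a number 0.3 percentage points higher from compound 1 to compound 3 (within the scatter) in this assay and so leaves the two aryl groups indistinguishable in this test. The entering group carries a hydrogen-bond donor and the leaving group a nitrile, yet the numbers of the two compounds stay within the scatter of each other. Nothing available explains this match.

The compounds shown leave open whether an unsubstituted phenyl would give a similar number. They also leave open how an aminomethyl group or a carboxylic acid on this aryl ring would fare.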